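Removing the chloro from the pyrazole of compound 1

The compounds below may be only part of what the source reports. "The series", "measured", "known", "first", "only" and "open" are said of these compounds alone.

Measured compounds:
compound 1 `C[C@@H]1CCCN1c1c(C#N)c2c(N)nc(Nc3cn(C)nc3Cl)nc2n1C`: 34 nM
compound 2 `C[C@@H]1CCCN1c1cc2c(N)ncnc2n1C`: 6830 nM
compound 3 `C[C@H]1CCCN1c1c(C#N)c2c(N)ncnc2n1C`: 5660 nM

The three compounds were tested in an assay on isolated protein for inhibition of Leucine-rich repeat serine/threonine-protein kinase 2 (Homo sapiens), read by TR-FRET and LanthaScreen, with stated times of 50 min and 30 min, in the presence of a further agent that is not named here; a lower number here means a stronger inhibitor, a higher number a weaker inhibitor. Compound 1 gives the lowest number of the three, and its gap to compound 3 and to compound 2 lies well beyond the scatter, so it is the strongest inhibitor of the set. Compounds 2 and 3 carry no (3-chloro-1-methyl-1H-pyrazol-4-yl)amino group at all, so neither pairs with compound 1 as a single change, and their values only show how much weaker the core is on its own.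

The unmeasured compound 4 `C[C@@H]1CCCN1c1c(C#N)c2c(N)nc(Nc3cnn(C)c3)nc2n1C` differs from compound 1 in one place: hydrogen in place of chloro on an aromatic carbon. Going from (3-chloro-1-methyl-1H-pyrazol-4-yl)amino to (1-methyl-1H-pyrazol-4-yl)amino keeps the whole group that sets compound 1 apart from compounds 2 and 3, so no large loss is expected. The step of a 2.4-fold higher number from compound 1 to compound 4 (0.37 log units; beyond the scatter) is expected to be small, toward a weaker inhibitor, and may stay within the scatter. Compound 4 is therefore estimated at 80 nM, with a range of 30 nM to 250 nM.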

Compound 4, half-maximal inhibitory concentration: 6 nM
Compound 4: the middle estimate sits 13-fold (1.12 log units) above what was measured, and the stated range ends above it.
By their numbers in this assay, from the lowest: compound 4; then compound 1; then compounds 3 and 2 (each within the scatter of the next).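

In this assay, the chloro of compound 1 proves not to be needed for strong inhibition: replacing it with hydrogen gives a 5.7-fold lower number from compound 1 to compound 4 (0.75 log units; beyond the scatter), a modest step but one beyond the scatter. This aromatic carbon, next to the ring atom that bears a large group, therefore gives a lower number with hydrogen than with chloro, a direction that compounds 1, 2 and 3 alone could not show. Nothing available here accounts for this step.

The compounds shown compare only hydrogen and chloro at this carbon, so it remains open where a fluoro, a methyl or a methoxy group would fall. Going by these compounds, it is also open whether the same step would hold with a different group in place of the (1-methyl-1H-pyrazol-4-yl)amino group's methyl.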